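Antiproliferative series on DU-145: nitro for cyano

This account rests on a few compounds, and the source may have more. Where it says the series, first, only, none or still open, it means among the compounds named here.

Measured compounds in a functional assay on DU-145 cells (Homo sapiens) for antiproliferative activity, read by propidium iodide staining, with a stated time of 96 h; on this read-out lower numbers stand for stronger inhibition and higher numbers for weaker inhibition:
- compound 1 `CC(O)(CS(=O)(=O)c1cccc(S(F)(F)(F)(F)F)c1)C(=O)Nc1ccc(C#N)cc1C(F)(F)F` gives 22100 nM
- compound 2 `CC(O)(CS(=O)(=O)c1cccc(S(F)(F)(F)(F)F)c1)C(=O)Nc1ccc([N+](=O)[O-])cc1C(F)(F)F` gives 100000 nM
- compound 3 `CC1(C)C(=O)N(c2ccc(C#N)cc2C(F)(F)F)C(=S)N1c1cccc(S(F)(F)(F)(F)F)c1` gives 100000 nM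

Compound 1 and compound 2 share one core and differ by nitro in place of cyano on an aromatic carbon; the step is a 4.5-fold higher number from compound 1 to compound 2 (0.66 log units; beyond the scatter). Compound 3 carries a different core, and the difference between the two cores is not broken down here. Compound 3 stands level with compound 2 at the digits printed, and together they give the highest numbers of the three; against compound 1, compound 3 shows the higher number.

Compound 4 `CC1(C)C(=O)N(c2ccc([N+](=O)[O-])cc2C(F)(F)F)C(=S)N1c1cccc(S(F)(F)(F)(F)F)c1` is not yet measured. It differs from compound 3 by nitro in place of cyano on an aromatic carbon, the same change as between compound 1 and compound 2. Because a 4.5-fold higher number from compound 1 to compound 2 (0.66 log units; beyond the scatter) ran toward higher numbers, compound 4 is expected to give a number no lower than that of compound 3, with a step estimated at no change at the digits printed from compound 3 to compound 4 (within the scatter). Compound 3 already gives 100000 nM, which together with the number of compound 2 is the highest of the three. The estimate for compound 4 in this assay is 100000 nM, expected between 60000 nM and 300000 nM.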

Compound 4, half-maximal inhibitory concentration: 100000 nM
For compound 4 middle estimate and measured number coincide at the digits printed, and the stated range covers the measured number.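

In this assay, the step with nitro in place of cyano on an aromatic carbon reads no change at the digits printed from compound 3 to compound 4 (within the scatter). Set beside the earlier step, the same change does not carry over at the same size from the core of compound 1 to the core of compound 3: the same change on two cores in this assay, a 4.5-fold higher number (0.66 log units; beyond the scatter) from compound 1 to compound 2 and no change at the digits printed (within the scatter) from compound 3 to compound 4, 4.5-fold (0.66 log units) apart, beyond the scatter of two such steps. This shows that, in these two pairs, the size of the step differs with the core; it does not show what in the cores produces the difference, and two pairs give no rule for any further core.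

The compounds shown leave open how other groups on the same aromatic carbon, such as an amine or a carboxylic acid in place of cyano or nitro, would read on either core. They also leave open whether the two cores would part in the same way with a chlorine atom in place of the pentafluorosulfanyl group.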